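A few compounds are considered here, and "the series" means these few. Any claim that something is new, unique, unknown or untested is made for them only; others in the source may bear on it.

In a physicochemical assay for lipophilicity, read by HPLC, at pH 7.5 (a higher number here means a more lipophilic compound, a lower number a more polar compound), compound 1 (`CCOc1ccccc1-c1ccc(-c2nc3cnccc3cc2C#N)cc1`) gives 3.8, the highest of the three numbers available. Compound 2 (`CC[C@@H](Nc1c(C#N)c(-c2ccc(-c3cccc(C)c3)cc2)nc2cnccc12)C(N)=O`) gives 3, and compound 3 (`CC[C@@H](Nc1c(C#N)c(-c2ccc(Br)cc2)nc2cnccc12)C(=O)O`), which carries a carboxyl group, gives 1.6; both lie beyond the scatter below compound 1. Compound 4 (`CCOc1ccccc1-c1ccc(-c2nc3cnccc3c(C[C@H](C)C(=O)O)c2C#N)cc1`) has 2-carboxypropyl in place of hydrogen on an aromatic carbon of compound 1, ortho to a cyano group and opposite the ring nitrogen: 2-carboxypropyl in place of hydrogen on an aromatic carbon. Among the compounds with values here, no measured pair isolates such a change, so the expectation leans on compound 3 at 1.6, the only measured compound with a carboxyl group. A fall beyond the scatter is expected, an estimated a number 1.70 log units lower from compound 1 to compound 4 (beyond the scatter). The expected value for compound 4 is 2.1, within a range of 1.4 to 2.8.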

Compound 4, distribution coefficient: 2.2
For compound 4 the middle estimate is 0.10 log units below the measured one, within the range that was stated.
By their numbers in this assay, from the lowest: compound 3; then compound 4; then compound 2; then compound 1.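

In this assay, 2-carboxypropyl in place of hydrogen on this aromatic carbon, ortho to a cyano group and opposite the ring nitrogen, gives a large step: a number 1.60 log units lower from compound 1 to compound 4 (beyond the scatter). Within the data shown here, this is the first single change on the core of compound 1 that can be read, and it shows that this position responds strongly to this group. No supporting measurement bears on why the step has this size. On these data alone, what a primary amide, a methyl ester or a plain propyl chain would give at this carbon stays open, as does the effect of the opposite stereocentre in the chain.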